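The source may report more compounds than this note shows. Statements on the series, on what has been measured and on what is new or still open speak of the compounds shown alone.

Compound 1 `Cc1ccc(N2CCN(C(=S)N/N=C3\C(=O)Nc4ccc(Cl)cc43)CC2)cc1`: 10100 nM
Compound 2 `O=C1Nc2ccc(Cl)cc2/C1=N/NC(=S)N1CCN(c2ccc(Cl)c(Cl)c2)CC1`: 7950 nM
Compound 3 `O=C1Nc2ccc(Cl)cc2/C1=N/NC(=S)N1CCN(c2ccc(F)cc2)CC1`: 8900 nM

In a functional assay on A549 cells (Homo sapiens) for inhibition, read by MTT assay, with a stated time of 72 h (a higher number here means a weaker inhibitor, a lower number a stronger inhibitor), compound 3 gives 8900 nM, the second highest of the three numbers. Its nearest neighbour is reached by a 1.1-fold higher number from compound 2 to compound 3 (0.05 log units; within the scatter), its furthest by a 1.1-fold lower number from compound 1 to compound 3 (0.05 log units; within the scatter).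

Compound 4 `O=C1Nc2ccc(Cl)cc2/C1=N/NC(=S)N1CCN(c2ccccc2[N+](=O)[O-])CC1` differs from compound 3 by one change: 2-nitrophenyl in place of 4-fluorophenyl on an amine nitrogen in a ring. The three measured steps all swap the aryl group on that same ring nitrogen: a 1.3-fold lower number from compound 1 to compound 2 (0.10 log units; within the scatter), a 1.1-fold lower number from compound 1 to compound 3 (0.05 log units; within the scatter) and a 1.1-fold higher number from compound 2 to compound 3 (0.05 log units; within the scatter), every one within the scatter. For the measured compounds named here, a nitro group has not been tested here, so no step shows its effect; the expectation in this assay is therefore no change beyond the scatter. Compound 4 is expected to give about 9000 nM, between 4000 nM and 20000 nM. The expected step is a 1.0-fold higher number from compound 3 to compound 4 (0.00 log units; within the scatter).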

Compound 4, half-maximal inhibitory concentration: 5580 nM
Beside the measured number, compound 4's estimate is 1.6-fold (0.21 log units) above it; the measured number falls inside the stated range.
By their numbers in this assay, from the lowest: compounds 4, 2, 3 and 1 (each within the scatter of the next).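

Adding 2-nitrophenyl extends the range of aryl groups tried on this amine nitrogen in a ring to one carrying hydrogen-bond acceptors, yet this assay still separates no pair of compounds: there is a 1.6-fold lower number from compound 3 to compound 4 (0.20 log units; within the scatter) and a 1.4-fold lower number from compound 2 to compound 4 (0.15 log units; within the scatter) and also a 1.8-fold lower number from compound 1 to compound 4 (0.26 log units; within the scatter). So far, this position has tolerated all four aryl groups without a change beyond the scatter. Nothing available here explains this result.

On these data alone, whether a phenyl ring bearing an amine or a carboxylic acid would go beyond the scatter remains open. The same applies to replacing the aryl group with a plain alkyl chain.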